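The source may hold more compounds than are shown below. What is called first, only, known or untested is meant among the compounds shown, and "the series" means these compounds.

Compound 1 `O=C/C=C/n1ccc(=O)[nH]c1=O`: 30000 nM
Compound 2 `O=C/C=C/n1cc(C(F)(F)F)c(=O)[nH]c1=O`: > 100000 nM

In a functional assay on HeLa cells (Homo sapiens) for inhibition (on this read-out lower numbers stand for stronger inhibition and higher numbers for weaker inhibition), compound 1 gives 30000 nM. From the compounds shown here alone, compound 2 stands at > 100000 nM, which is a limit of the assay and not a number, so its true position is unknown. It therefore marks the weak end of this small set, as the limit of > 100000 nM in this assay, at which 1 of the 2 values shown sits, shows.

Compound 3 `O=C/C=C/n1cc(CO)c(=O)[nH]c1=O` keeps the shared core and changes one group: hydroxymethyl in place of trifluoromethyl on an aromatic carbon. In words, hydroxymethyl takes the place of trifluoromethyl on an aromatic carbon.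

Within the data shown here, only one measured step bears on this change. Putting trifluoromethyl on that same carbon in place of hydrogen gave an at least 3.3-fold higher number from compound 1 to compound 2 (0.52 log units; beyond the scatter). Among the measured compounds shown here, no measured compound carries hydroxymethyl, so the effect of that group is open. Removing trifluoromethyl may undo part of that loss, and so a lower number is expected, near that of compound 1 at 30000 nM.

The expected change is an at least 2.5-fold lower number from compound 2 to compound 3 (0.39 log units; beyond the scatter), and its size is uncertain given the limit. For compound 3 the estimated value is 40000 nM, with an expected range of 12000 nM to 100000 nM.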

Compound 3, half-maximal inhibitory concentration: > 100000 nM
Compound 3: only a limit was reported; the forecaster's own chance of this, stated with the estimate: 35%; at least 2.5-fold (0.39 log units) between middle value and limit.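

In this assay, hydroxymethyl in place of hydrogen on this aromatic carbon gives an at least 3.3-fold higher number from compound 1 to compound 3 (0.52 log units; beyond the scatter), so this group does not return the read-out to the level of compound 1. Among these three compounds, both groups tried on this carbon, trifluoromethyl and hydroxymethyl, therefore give a higher number than hydrogen does, which means the loss seen earlier is not unique to trifluoromethyl. Compound 2 and compound 3 both end at a limit of the assay rather than at a true number, so the step between them cannot be read and neither can be ranked above the other: the limit of > 100000 nM in this assay, at which 2 of the 3 values shown sit.

From the compounds shown here alone, how far beyond that limit each of the two compounds lies remains unknown, and so does whether replacing trifluoromethyl with hydroxymethyl changes anything at all. Also open, going by these compounds, is whether any group on this carbon can match or improve on hydrogen, for example a single fluorine atom, a methyl group, an amine or a carboxylic acid.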